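This account rests on a few compounds, and the source may have more. Where it says the series, first, only, none or still open, it means among the compounds named here.

Measured so far in a functional assay on A-375 cells (Homo sapiens) for inhibition, read by CCK-8 assay, with a stated time of 72 h, tested at 8 uM; a higher number here means more inhibition of growth at the concentration tested, a lower number less inhibition of growth:

- compound 1 `COc1ccc(SCc2ccc(C(=O)Nc3ccccc3N)cc2)cc1` gives 81.8%
- compound 2 `Cc1ccc(SCc2ccc(/C=C/C(=O)Nc3ccccc3N)cc2)cc1` gives 31.2%
- compound 3 `Nc1ccccc1NC(=O)/C=C/c1ccc(CSc2ccc(F)cc2)cc1` gives 24.6%

Compound 1 stands highest of these three, and both other compounds lie beyond the scatter from it. The next compound to be tested is compound 4 `Cc1ccc(SCc2ccc(C(=O)Nc3ccccc3N)cc2)cc1`, which keeps the core of compound 1 and changes one small group. The difference is methyl in place of methoxy on an aromatic carbon in other words, methyl in place of methoxy on an aromatic carbon, para to a large group.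

Going by the values given here, no measured pair makes this exact swap. The closest evidence is a swap of fluoro in place of methyl on an aromatic carbon (a number 6.6 percentage points lower from compound 2 to compound 3 (within the scatter)). That step stayed small, but it was taken on compounds whose core differs from that of compound 1, so it is only a loose guide. On that limited basis, no step beyond the scatter is expected in this assay for this change, although a modest drop remains possible. The estimated change is (a number 6.8 percentage points lower from compound 1 to compound 4 (within the scatter)). The expected value for compound 4 is 75% (estimated range 55% to 90%).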

Compound 4, percent growth inhibition at one concentration: 67%
Estimate against measurement, compound 4: 8 percentage points above, within the range that was stated.
By their numbers in this assay, from the lowest: compounds 3 and 2 (each within the scatter of the next); then compound 4; then compound 1.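

Placing 4-methylphenyl where compound 1 carries 4-methoxyphenyl gives the only direct comparison of these two groups, and in this assay it produces a number 14.8 percentage points lower from compound 1 to compound 4 (beyond the scatter). On this core, then, methoxy and methyl are not interchangeable at this place: the step is modest but lies beyond the scatter, whereas the one other swap of a small group shown here, made on a different core, gave a number 6.6 percentage points lower from compound 2 to compound 3 (within the scatter), which stayed within it. No measurement at hand says why the loss of methoxy lowers the growth inhibition.

The compounds shown leave open how other groups would fare at this place on the shared core, such as an amine, a hydroxyl, fluoro or a longer chain like ethoxy, and so whether the higher number of compound 1 is particular to methoxy. They also leave open whether the same change from methoxy to methyl would give a step of similar size on the core of compound 2 and compound 3.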